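The compounds below may be only part of what the source reports. "The series", "measured", "known", "first", "only" and "open" are said of these compounds alone.

Working notes on the series. Compound 1 `CN(C)C1CCC(COCc2cc(C(F)(F)F)cc(C(F)(F)F)c2)(c2ccccc2)C1` and compound 2 `FC(F)(F)c1cc(COCC2(c3ccccc3)CCC(NC3CC3)C2)cc(C(F)(F)F)c1` are built on one core; compound 3 `CN(C)C1CCC(COCc2cc(C(F)(F)F)cc(C(F)(F)F)c2)(c2ccccc2)CC1` and compound 4 `FC(F)(F)c1cc(COCC2(c3ccccc3)CCC(NC3CC3)CC2)cc(C(F)(F)F)c1` are built on another, and the difference between the two cores is not broken down here. In an assay on isolated protein for antagonist activity at Substance-P receptor (Homo sapiens) (on this read-out higher numbers stand for weaker inhibition and lower numbers for stronger inhibition), compound 1 gives 8 nM, and compound 2 gives 16 nM. The change between them, (cyclopropylamino in place of dimethylamino on a saturated ring carbon), made a step of a 2.0-fold higher number from compound 1 to compound 2 (0.30 log units; within the scatter). Compound 3 gives 48 nM in this assay, the highest number of the three measured, with its gaps to compound 2 and to compound 1 both beyond the scatter.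

Compound 4 carries the same kind of change on its own core, (cyclopropylamino in place of dimethylamino on a saturated ring carbon). The place is not identical: here the ring is six-membered rather than five-membered, and the group sits three ring bonds, rather than two, from the ring atom that bears a large group and from the ring atom that bears a phenyl group. Among the measured compounds shown here, only one earlier instance of this change exists, and it lies within the scatter, so a similarly small upward shift is the natural expectation, with wide uncertainty from the single precedent and the different core.

Compound 4 is expected to move by a 1.9-fold higher number from compound 3 to compound 4 (0.27 log units; within the scatter) in this assay, resting on the step of a 2.0-fold higher number from compound 1 to compound 2 (0.30 log units; within the scatter). Compound 4 is therefore estimated at 90 nM in this assay. The expected range for compound 4 runs from 40 nM to 220 nM.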

Compound 4, half-maximal inhibitory concentration: 74 nM
Estimate against measurement, compound 4: 1.2-fold (0.09 log units) above; measured number inside the range.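

In this assay, cyclopropylamino in place of dimethylamino on a saturated ring carbon of the six-membered ring gives a 1.5-fold higher number from compound 3 to compound 4 (0.19 log units; within the scatter) and so stands with the earlier step on the core of compound 1, with no difference between the two that the data can resolve: the same change on two cores in this assay, a 2.0-fold higher number (0.30 log units; within the scatter) from compound 1 to compound 2 and a 1.5-fold higher number (0.19 log units; within the scatter) from compound 3 to compound 4, 1.3-fold (0.11 log units) apart, within the scatter of two such steps. Within this series, the step on the core of compound 1 therefore served as a fair guide to the step on the core of compound 3, and neither step moves the number beyond the scatter. This does not show that the change has a real effect of any particular size, since both steps are small enough to be scatter alone, and two pairs say nothing about how the change would behave on a third core.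

The compounds shown leave open how other groups at this ring carbon would compare, such as a primary amine, an azetidine, a morpholine or a longer chain on the nitrogen such as propylamino. They also leave open whether an amide in place of the amine would keep the numbers of either core in the same range.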